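Adding an amino group to the pyridyl ring of compound 2

The compounds below may be only part of what the source reports. "The series", "measured", "known", "first", "only" and "open" are said of these compounds alone.

Measured compounds:
Compound 1: `Cc1csc(-c2cc(NC(=O)c3ccc(OCc4ccccn4)cc3)c(C)cc2C)n1` gives 147 mL.min-1.g-1
Compound 2: `Cc1cc(C)c(-c2ccccn2)cc1NC(=O)c1ccc(OCc2ccccn2)cc1` gives 296 mL.min-1.g-1

Of the compounds shown here, two have been measured in an ADME assay on microsomes from liver (Rattus norvegicus) for metabolic stability; a lower number here means slower removal, a higher number faster removal of the compound. Compound 1 `Cc1csc(-c2cc(NC(=O)c3ccc(OCc4ccccn4)cc3)c(C)cc2C)n1` gives 147 mL.min-1.g-1. Among the measured compounds shown here, compound 2 `Cc1cc(C)c(-c2ccccn2)cc1NC(=O)c1ccc(OCc2ccccn2)cc1` gives 296 mL.min-1.g-1, the higher of the two numbers, though the only step connecting them, a 2.0-fold higher number from compound 1 to compound 2 (0.30 log units; within the scatter), stays within the scatter, so neither compound can be called more or less stable than the other in this assay.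

Compound 3 `Cc1cc(C)c(-c2ccc(N)cn2)cc1NC(=O)c1ccc(OCc2ccccn2)cc1` has not yet been measured. It differs from compound 2 in one place: amino in place of hydrogen on an aromatic carbon. For the measured compounds named here, no measured step shows what an amino group added in this way does in this assay; the single step from compound 1 to compound 2 concerns the exchange of one aromatic group for another and does not bear on it. With nothing to rest on beyond the value of compound 2, the step is expected to be a 1.3-fold lower number from compound 2 to compound 3 (0.11 log units; within the scatter), that is, no change beyond the scatter. Compound 3 is therefore estimated at 230 mL.min-1.g-1, within a range from 90 mL.min-1.g-1 to 550 mL.min-1.g-1.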

Compound 3, intrinsic clearance in microsomes: 32 mL.min-1.g-1
Compound 3: the middle estimate sits 7.2-fold (0.86 log units) above what was measured, outside the stated range (below it).
By their numbers in this assay, from the lowest: compound 3; then compounds 1 and 2 (each within the scatter of the next).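

In this assay, the amino group, on the aromatic carbon two atoms from the ring nitrogen and para to a large group, gives a 9.3-fold lower number from compound 2 to compound 3 (0.97 log units; beyond the scatter) and so shows that this position responds to a single added group with a step beyond the scatter, which the earlier pair could not show. The exchange of one aromatic group for another had stayed within the scatter in that pair, whereas 5-aminopyridin-2-yl in place of 4-methyl-1,3-thiazol-2-yl gives a 4.6-fold lower number from compound 1 to compound 3 (0.66 log units; beyond the scatter) and thus brings the exchange beyond the scatter once the amino group is present. Nothing measured here bears on why the amino group changes the number so strongly.

Whether the step belongs to the amino group itself remains open, since a hydroxyl, a methoxy or a methylamino group on the same carbon is not among the compounds shown. Also open, going by these compounds, is whether an amino group on another carbon of the same ring, or on the 4-methyl-1,3-thiazol-2-yl ring of compound 1, would give a step of similar size.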